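The source may report more compounds than this note shows. Statements on the series, on what has been measured and on what is new or still open speak of the compounds shown alone.

Compound 1 `COc1cc(O)cc(O)c1C(=O)/C=C/c1ccc(O)cc1`: in a functional assay on A549 cells (Homo sapiens) for inhibition, read by MTT assay, with a stated time of 72 h (a lower number here means a stronger inhibitor, a higher number a weaker inhibitor), compound 1 gives > 50000 nM, which is a limit of the assay and not a number.
Compound 2 `COc1ccc(/C=C/C(=O)c2c(O)cc(O)cc2OC)cc1`: in this assay compound 2 gives > 50000 nM, again only a limit.
Compound 3 `COc1cc(/C=C/C(=O)c2c(O)cc(O)cc2OC)ccc1O`: in this assay compound 3 gives > 50000 nM, also a limit.

All three measured compounds therefore stand at one point, (the limit of > 50000 nM in this assay, at which 3 of the 3 values shown sit), and no order among them can be read. The change from compound 2 to compound 1 is hydrogen in place of methyl on an oxygen on an aromatic ring, and the step it made is a step that the two limits leave unreadable from compound 2 to compound 1. The further step that the two limits leave unreadable from compound 1 to compound 3 is unreadable for the same reason. How the core of compound 2 differs from the core of compound 3 is not broken down here.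

Compound 4 `COc1cc(O)cc(O)c1C(=O)/C=C/c1ccc(O)c(O)c1` differs from compound 3 by hydrogen in place of methyl on an oxygen on an aromatic ring, the same change that was made from compound 2 to compound 1, at the same kind of place. Since that earlier step that the two limits leave unreadable from compound 2 to compound 1 gave no readable size, the expected step of a number no higher from compound 3 to compound 4 (the limit leaves the size open) rests only on all three measured values sitting at the limit of > 50000 nM in this assay, at which 3 of the 3 values shown sit. Compound 4 is estimated at about 50000 nM in this assay, most likely reported once more as a limit, with an expected range from 15000 nM to 150000 nM.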

Compound 4, half-maximal inhibitory concentration: 11800 nM
For compound 4 the middle estimate is 4.2-fold (0.63 log units) above the measured one; measured number outside the range, below it.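

Two single changes now give readable steps in this assay: methoxy to hydroxy gives an at least 4.2-fold lower number from compound 3 to compound 4 (0.62 log units; beyond the scatter), and adding a hydroxy gives an at least 4.2-fold lower number from compound 1 to compound 4 (0.62 log units; beyond the scatter). The same methoxy to hydroxy change on the core of compound 2 cannot be read, and neither can the other earlier step, because the values involved are limits of the assay and not numbers: the limit of > 50000 nM in this assay, at which 3 of the 4 values shown sit. So the change has a readable effect on one core only, which does not show that it carries from one core to another, and each new step gives only a smallest size, since its starting value is a limit.

The compounds shown leave open whether the same change would give a step of similar size on a core that starts from a measured number rather than a limit. They also leave open what an amine or a carboxylic acid would do in place of the hydroxy.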